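From methoxy to fluoro: compound 3 to compound 4

A few compounds are considered here, and "the series" means these few. Any claim that something is new, unique, unknown or untested is made for them only; others in the source may bear on it.

In a functional assay on MOLT-3 cells (Homo sapiens) for antiproliferative activity (on this read-out lower numbers stand for stronger inhibition and higher numbers for weaker inhibition), compound 3 `COc1ccc(NC(=O)c2cccc(NC(=O)C(C)Br)c2)cc1` gives 800 nM, the lower of the two actual numbers in the series. Compound 1 `CCCNC(=O)c1cccc(NC(=O)C(C)Br)c1` gives 8940 nM, and its gap to compound 3 lies beyond the scatter. Compound 2 `CCCCNC(=O)c1cccc(NC(=O)C(C)Br)c1` reaches only a limit, > 10000 nM, and provides no number.

The change under consideration leads to compound 4 `CC(Br)C(=O)Nc1cccc(C(=O)Nc2ccc(F)cc2)c1` and puts fluoro in place of methoxy on an aromatic carbon of a six-membered aromatic ring of carbon only, para to a large group: fluoro in place of methoxy on an aromatic carbon.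

Within the data shown here, the one measured step, an at least 1.1-fold higher number from compound 1 to compound 2 (0.04 log units; that floor lies within the scatter), lies on a saturated chain and not on this ring. Its floor lies within the scatter, so it gives no size for the present change. Among the measured compounds shown here, no measured step covers a replacement on the ring, and the expectation therefore starts from compound 3 at 800 nM, with wide margins. No step beyond the scatter is expected, although a slightly higher number is the more likely direction. The expected step is a 1.5-fold higher number from compound 3 to compound 4 (0.18 log units; within the scatter). For compound 4 the estimated value in this assay is 1200 nM, with an expected range of 350 nM to 4000 nM.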

Compound 4, half-maximal inhibitory concentration: 2000 nM
For compound 4 the middle estimate is 1.7-fold (0.22 log units) below the measured one; the measured number falls inside the stated range.
By their numbers in this assay, from the lowest: compound 3; then compound 4; then compound 1. At a limit, above all of these: compound 2.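

In this assay, among these compounds, the change from methoxy to fluoro on an aromatic carbon, para to a large group, gives a 2.5-fold higher number from compound 3 to compound 4 (0.40 log units; beyond the scatter), so this ring carbon responds to its substituent, which the earlier compounds could not show. The 4-fluorophenyl group on the amide-type nitrogen still compares well with the saturated chains, with a 4.5-fold lower number from compound 1 to compound 4 (0.65 log units; beyond the scatter) for the replacement of propyl and an at least 5.0-fold lower number from compound 2 to compound 4 (0.69 log units; beyond the scatter) for the replacement of butyl. Compound 2 stands at a limit and gives no number, so the second of these steps is only a floor: the limit of > 10000 nM in this assay, at which 1 of the 4 values shown sits.

Only methoxy and fluoro are compared at this ring carbon, so a single pair cannot separate the effect of losing one group from that of gaining the other, and a chloro, hydroxyl or amine group there would be needed to test whether the order holds more widely. The bromo-bearing amide stays the same in all the compounds shown, so the result of putting chloro in place of bromo, or a longer chain in place of its methyl, remains open.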